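Side-chain hydroxyl variation in a shared-core antiproliferative series

This account rests on a few compounds, and the source may have more. Where it says the series, first, only, none or still open, it means among the compounds named here.

Of the compounds shown here, two have numbers so far. In a functional assay on MCF7 cells (Homo sapiens) for antiproliferative activity, read by MTT assay, with a stated time of 48 h, tested at 100 uM (a lower number here means a stronger effect, a higher number a weaker effect of the compound at the concentration tested), compound 1 `OC(CCn1nc2c(Br)c(Br)c(Br)c(Br)c2n1)c1cccc(Cl)c1` gives 0.5%. In this assay compound 2 `C[C@H](O)CCn1nc2c(Br)c(Br)c(Br)c(Br)c2n1` gives 6%, the highest of the two numbers shown, though the number for compound 1 lies within the scatter of it, so no order between the two can be read. Both numbers sit close to the bottom of the read-out, which for an activity percentage at the tested concentration means a strong effect in each case.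

Compound 3 `OCC(O)Cn1nc2c(Br)c(Br)c(Br)c(Br)c2n1` has not yet been measured. Relative to compound 2 the change is 1,2-dihydroxyethyl in place of 2-hydroxypropyl on a saturated chain carbon bound to an aromatic nitrogen. Among the compounds with values here, no step between measured compounds is available to calibrate a change of this kind; the only guide is that the two measured compounds, which differ considerably in their side chains, give numbers within the scatter of one another. The step is therefore expected to be a number 2 percentage points lower from compound 2 to compound 3 (within the scatter), not beyond the scatter in either direction. Compound 3 is expected to give 4%, with a likely range from 0% to 15%.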

Compound 3, a percentage reported as activity, at one concentration (the size of the read-out at that concentration, not a potency): 8%
Beside the measured number, compound 3's estimate is 4 percentage points below it; the measured number falls inside the stated range.
By their numbers in this assay, from the lowest: compounds 1, 2 and 3 (each within the scatter of the next).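

In this assay, within the data shown here, the exchange of 2-hydroxypropyl for 1,2-dihydroxyethyl on a saturated chain carbon bound to an aromatic nitrogen gives a number 2 percentage points higher from compound 2 to compound 3 (within the scatter), the first step that can be read at one place. At this place, then, the added hydrogen-bond donor and acceptor of 1,2-dihydroxyethyl and the loss of the defined stereocentre of 2-hydroxypropyl come with no change beyond the scatter, and the read-out stays close to its bottom at the single tested concentration. No measurement is at hand that would explain this step.

As far as these compounds go, whether a side chain without a hydroxyl, such as one ending in an amine or a carboxylic acid, or a longer chain at the same place would lift the number away from the bottom of the read-out remains open. Also open, from the compounds shown here alone, is whether compound 2 and compound 3 would separate at lower concentrations, since a read-out this close to its bottom at one concentration gives no measure of potency.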